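Replacing the amine substituent of compound 3

This account rests on a few compounds, and the source may have more. Where it says the series, first, only, none or still open, it means among the compounds named here.

In a functional assay on MDA-MB-453 cells (Homo sapiens) for antiproliferative activity, read by MTT assay, with a stated time of 72 h (a higher number here means a weaker inhibitor, a lower number a stronger inhibitor), compound 3 (`Cc1cc(N/C=C2\C(=O)N(c3ccccc3)N=C2c2ccccc2)n[nH]1`) gives 10200 nM and compound 2 (`O=C1/C(=C\Nc2cc(-c3ccco3)[nH]n2)C(c2ccccc2)=NN1c1ccccc1`) gives 12400 nM as two values within the scatter of each other. Compound 1 (`CSC[C@H](N/C=C1\C(=O)NN=C1c1ccccc1)C(=O)O`) gives 105000 nM as a clearly higher number than either of them.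

Compound 4 (`CSC[C@H](N/C=C1\C(=O)N(c2ccccc2)N=C1c1ccccc1)C(=O)O`) has 1-carboxy-2-(methylsulfanyl)ethyl in place of 5-methyl-1H-pyrazol-3-yl on an amine nitrogen. Going by the values given here, the only measured step (a 1.2-fold lower number from compound 2 to compound 3 (0.08 log units; within the scatter)) stayed within the scatter, but it kept an aromatic ring on the amine nitrogen, so it offers little guidance for this change. The closer reference is compound 1, which carries the same 1-carboxy-2-(methylsulfanyl)ethyl on its amine nitrogen and gives 105000 nM even though its core differs from that of compound 4. A move towards a higher number is therefore expected, probably beyond the scatter but short of the full gap to compound 1. The estimated change is a 3.4-fold higher number from compound 3 to compound 4 (0.54 log units; beyond the scatter) in that direction. In this assay compound 4 is estimated at 35000 nM within an expected range from 11000 nM to 110000 nM for now.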

Compound 4, half-maximal inhibitory concentration: 9460 nM
Estimate against measurement, compound 4: 3.7-fold (0.57 log units) above; the whole stated range lies above it.
By their numbers in this assay, from the lowest: compounds 4, 3 and 2 (each within the scatter of the next); then compound 1.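

In this assay the amine nitrogen carries an open chain as readily as a ring-bearing substituent, with a 1.1-fold lower number from compound 3 to compound 4 (0.03 log units; within the scatter) and a 1.3-fold lower number from compound 2 to compound 4 (0.12 log units; within the scatter) as the steps to 1-carboxy-2-(methylsulfanyl)ethyl. The large step lies elsewhere, at an 11-fold lower number from compound 1 to compound 4 (1.05 log units; beyond the scatter) with phenyl in place of hydrogen on an amide-type nitrogen in a ring, so the high number of compound 1 goes with the missing phenyl and not with the chain it shares with compound 4. Nothing measured here accounts for either result.

As far as these compounds go, whether the carboxylic acid or the methylsulfanyl part of the chain matters stays open, as does the outcome for an ester, an amide or a longer chain at this amine nitrogen. From the compounds shown here alone, it is also open whether the mirror-image stereocentre would behave alike, and whether methyl or benzyl could stand in for phenyl on the ring nitrogen.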